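Mesityl replacement on the aminomethyl aryl position

This account rests on a few compounds, and the source may have more. Where it says the series, first, only, none or still open, it means among the compounds named here.

Working notes on the series. Compound 3 `COc1cccc(C(Nc2ccccn2)c2ccc3cccnc3c2O)c1` stands at the highest number of the three measured compounds: in an assay for inhibition of protein disulfide-isomerase (Homo sapiens), with a stated time of 1 h (on this read-out higher numbers stand for weaker inhibition and lower numbers for stronger inhibition), compound 3 gives 2860 nM, while compound 1 `Oc1cccc(C(Nc2ccccn2)c2ccc3cccnc3c2O)c1Cl` gives 370 nM and compound 2 `Oc1c(C(Nc2ccccn2)c2ccccc2F)ccc2cccnc12` gives 470 nM. The two steps leading to compound 3 both raise the number: a 7.7-fold higher number from compound 1 to compound 3 (0.89 log units; beyond the scatter) and a 6.1-fold higher number from compound 2 to compound 3 (0.78 log units; beyond the scatter); between compound 1 and compound 2 the step is a 1.3-fold higher number from compound 1 to compound 2 (0.10 log units; within the scatter).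

Compound 4 `Cc1cc(C)c(C(Nc2ccccn2)c2ccc3cccnc3c2O)c(C)c1` differs from compound 3 in one place: 2,4,6-trimethylphenyl in place of 3-methoxyphenyl on a saturated chain carbon bound to an aromatic carbon and a nitrogen on an aromatic ring. Among the measured compounds shown here, no measured step carries a 2,4,6-trimethylphenyl, so the bearing of the earlier steps is indirect. Both steps into compound 3 replaced another substituted phenyl with 3-methoxyphenyl and moved the number up by a modest amount. Replacing the 3-methoxyphenyl with a different substituted phenyl is expected to move the number back, though not necessarily to the level of compound 1 or compound 2. The step from compound 3 to compound 4 is therefore estimated at a 3.6-fold lower number from compound 3 to compound 4 (0.55 log units; beyond the scatter). Compound 4 is expected to give about 800 nM in this assay, within a range from 250 nM to 2500 nM.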

Compound 4, half-maximal inhibitory concentration: 190 nM
For compound 4 the middle estimate is 4.2-fold (0.62 log units) above the measured one, outside the stated range (below it).
By their numbers in this assay, from the lowest: compounds 4, 1 and 2 (each within the scatter of the next, the first and the last beyond it); then compound 3.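

In this assay, among the compounds shown here, the largest step so far is a 15-fold lower number from compound 3 to compound 4 (1.18 log units; beyond the scatter), which shows that this position on a saturated chain carbon bound to an aromatic carbon and a nitrogen on an aromatic ring can hold a 2,4,6-trimethylphenyl with a low number. The same group also gives a 2.5-fold lower number from compound 2 to compound 4 (0.39 log units; beyond the scatter), which is beyond the scatter, whereas a 1.9-fold lower number from compound 1 to compound 4 (0.29 log units; within the scatter) lies within it. As the 2,4,6-trimethylphenyl holds carbon only, a low number here does not require the hydroxyl or the chlorine of compound 1.

No available evidence accounts for these steps. Going by these compounds, it remains open whether a phenyl with a single methyl group would give a similarly low number, and whether a cyclohexyl or a pyridyl ring would be accepted at this position.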